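Removing one fluorine from compound 3: expected cytotoxicity

The compounds below may be only part of what the source reports. "The series", "measured", "known", "first", "only" and "open" are said of these compounds alone.

Compound 1, `Cc1ccc2[nH]c(=O)c(CN(Cc3ccc(O)cc3)Cc3ccc(C(C)(C)C)cc3)cc2c1`: in a toxicity assay on MDCK cells (Canis lupus familiaris) for cytotoxicity, read by crystal violet staining, with a stated time of 48 h (on this read-out higher numbers stand for lower toxicity in this test and lower numbers for higher toxicity in this test), compound 1 gives 4900 nM.
Compound 2, `CCCOc1ccc(CN(Cc2ccc(C(C)(C)C)cc2)Cc2cc3cc(C)ccc3[nH]c2=O)cc1`: in this assay compound 2 gives > 5000 nM, which is a limit of the assay and not a number.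
Compound 3, `Cc1ccc2[nH]c(=O)c(CN(Cc3ccc(OC(F)(F)F)cc3)Cc3ccc(C(C)(C)C)cc3)cc2c1`: in this assay compound 3 gives > 5000 nM, again a limit of the assay and not a number.

Compound 3 therefore stands at the ceiling of the shown numbers, a position shared with the limit of > 5000 nM in this assay, at which 2 of the 3 values shown sit. Compound 4, `Cc1ccc2[nH]c(=O)c(CN(Cc3ccc(OC(F)F)cc3)Cc3ccc(C(C)(C)C)cc3)cc2c1`, differs from compound 3 by hydrogen in place of fluoro on a saturated chain carbon bound to two fluorine atoms and an oxygen on an aromatic ring. Within the data shown here, the steps that bear on this change are an at least 1.0-fold higher number from compound 1 to compound 3 (0.00 log units; that floor lies within the scatter) and an at least 1.0-fold higher number from compound 1 to compound 2 (0.00 log units; that floor lies within the scatter), both sitting at a floor within the scatter, while a step that the two limits leave unreadable from compound 2 to compound 3. Nothing among these steps points to a move beyond the scatter, so the expected step is a step that the limit leaves unreadable from compound 3 to compound 4. Compound 4 is accordingly estimated at 6000 nM in this assay, with a range from 2500 nM to 15000 nM.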

Compound 4, half-maximal cytotoxic concentration: > 5000 nM
Compound 4 ended at the assay's limit; the forecaster's own chance of this, stated with the estimate: 65%; the middle value lies beyond the limit too.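

With 4-(difluoromethoxy)phenyl in place of 4-(trifluoromethoxy)phenyl, compound 4 also stays at the ceiling of this assay, so losing one fluorine brings no readable drop at this position: the limit of > 5000 nM in this assay, at which 3 of the 4 values shown sit.

Among these compounds, the one step that can be read is an at least 1.0-fold higher number from compound 1 to compound 4 (0.00 log units; that floor lies within the scatter), while the steps from compound 2 and compound 3 to compound 4 cannot be read.

The compounds shown leave open how far past the limit compound 2, compound 3 and compound 4 lie. They also leave open whether an amine or a carboxylic acid at this place would give a number inside the range of the assay.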